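Urea-linked series: aryl swap at the terminal anilide nitrogen

The compounds below may be only part of what the source reports. "The series", "measured", "known", "first", "only" and "open" are said of these compounds alone.

Measured so far:
- compound 1 `COc1ccc(NC(=O)Nc2nnc(Sc3ncnc4scc(-c5ccncc5)c34)s2)cc1` — 9900 nM in a functional assay on PC-3 cells (Homo sapiens) for antiproliferative activity, read by MTT assay, with a stated time of 48 h; on this read-out lower numbers stand for stronger inhibition and higher numbers for weaker inhibition
- compound 2 `COc1cccc(NC(=O)Nc2nnc(Sc3ncnc4scc(-c5ccncc5)c34)s2)c1` — 6800 nM in this assay

Compound 1 has the highest of the two numbers recorded; its nearest neighbour is compound 2, and the step of a 1.5-fold lower number from compound 1 to compound 2 (0.16 log units; within the scatter) leaves the pair indistinguishable. For the measured compounds named here, the only measured step therefore concerns moving the methoxy group around the ring, not replacing it.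

Compound 3 `O=C(Nc1cccc(F)c1)Nc1nnc(Sc2ncnc3scc(-c4ccncc4)c23)s1` carries the change (3-fluorophenyl in place of 4-methoxyphenyl on an amide-type nitrogen). No measured pair swaps the methoxy group for a fluorine, so nothing shown speaks directly to this change; the one step available, from compound 1 to compound 2, stayed within the scatter, and the shared core is untouched. The expectation is accordingly a step of a 1.2-fold lower number from compound 1 to compound 3 (0.09 log units; within the scatter), none beyond the scatter in either direction. Compound 3 is estimated at 8000 nM, with a range from 3000 nM to 20000 nM.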

Compound 3, half-maximal inhibitory concentration: 6600 nM
The estimate for compound 3 lay 1.2-fold (0.08 log units) above the measured number, and the stated range covers the measured number.
By their numbers in this assay, from the lowest: compounds 3, 2 and 1 (each within the scatter of the next).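

The swap of 3-fluorophenyl for 4-methoxyphenyl on the amide-type nitrogen gives a 1.5-fold lower number from compound 1 to compound 3 (0.18 log units; within the scatter) in this assay and so does not separate the two compounds. Fluoro in place of methoxy on an aromatic carbon, the one pair shown that changes the substituent alone, gives a 1.0-fold lower number from compound 2 to compound 3 (0.01 log units; within the scatter) and extends the picture from moving the methoxy group to replacing it: across compounds 1, 2 and 3, neither kind of change at this position takes a step beyond the scatter. Nothing available bears on why these numbers stay so close.

From the compounds shown here alone, whether an amine or a carboxylic acid on the phenyl ring, or a longer chain in its place, would move the number beyond the scatter remains open. So does the effect of any change to the shared core, which all three compounds carry unchanged.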